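This account rests on a few compounds, and the source may have more. Where it says the series, first, only, none or still open, it means among the compounds named here.

Measured compounds in this series:

compound 1, `NC/C=C(\CO)C(=O)O` — in an assay for inhibition of 4-aminobutyrate aminotransferase, mitochondrial (Sus scrofa) (a lower number here means a stronger inhibitor, a higher number a weaker inhibitor), compound 1 gives 5000 nM
compound 2, `NC/C=C(\CF)C(=O)O` — in this assay compound 2 gives 19000 nM

Within the data shown here, compound 2 holds the higher of the two numbers so far; its nearest neighbour is compound 1, and the only measured step, a 3.8-fold higher number from compound 1 to compound 2 (0.58 log units; beyond the scatter), is a modest weakening that lies beyond the scatter.

The next compound, compound 3, `NC/C=C(\CCl)C(=O)O`, differs from compound 2 by chloro in place of fluoro on a saturated chain carbon bound to a double-bonded chain carbon. Among the measured compounds shown here, no measured step exchanges one halogen for another at this position; the single step that bears on the place, a 3.8-fold higher number from compound 1 to compound 2 (0.58 log units; beyond the scatter), exchanged a hydroxy for a halogen there and gave a modest loss, so the site tolerates a halogen without a large swing. For the measured compounds named here, with only that step to go on, the expectation for compound 3 is a small movement, a 1.3-fold higher number from compound 2 to compound 3 (0.12 log units; within the scatter), not firmly beyond the scatter and leaning if anything toward a weaker inhibitor. Compound 3 is therefore estimated at 25000 nM, with a range from 8000 nM to 75000 nM.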

Compound 3, inhibition constant: 24000 nM
Compound 3: the middle estimate sits 1.0-fold (0.02 log units) above what was measured; the range from low to high includes it.
By their numbers in this assay, from the lowest: compound 1; then compounds 2 and 3 (each within the scatter of the next).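

In this assay, among these compounds, the first exchange of one halogen for another on a saturated chain carbon bound to a double-bonded chain carbon gives a 1.3-fold higher number from compound 2 to compound 3 (0.10 log units; within the scatter), so fluoromethyl and chloromethyl cannot be told apart at this position. The comparison with the hydroxy group now rests on two halogens rather than one: chloro in place of hydroxy gives a 4.8-fold higher number from compound 1 to compound 3 (0.68 log units; beyond the scatter) and sits alongside a 3.8-fold higher number from compound 1 to compound 2 (0.58 log units; beyond the scatter) as a second modest weakening, which shows that the loss is not confined to fluoro among the groups compared here. No supporting data bear on why either halogen differs from hydroxy or why the two halogens match.

Still open, on these data alone, is whether bromo or iodo at this position would stay level with compound 2 and compound 3, and whether methoxy or amino would stay closer to compound 1. A longer chain carrying the hydroxy group, such as hydroxyethyl in place of the hydroxymethyl of compound 1, is also untested among the compounds shown, so the reach of this position beyond a single carbon remains unknown.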